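A few compounds are considered here, and "the series" means these few. Any claim that something is new, unique, unknown or untested is made for them only; others in the source may bear on it.

Working notes on the series. Among the measured compounds shown here, compound 2 `O=C(Nc1ccc(-n2ccc3c(NC(=O)c4ccccc4)ncnc32)cc1)Nc1cccc(Cl)c1Cl` has, in an ADME assay on HS27 cells (Homo sapiens) for antiproliferative activity, read by MTT assay, with a stated time of 24 h (a lower number here means a stronger inhibitor, a higher number a weaker inhibitor), the value 7800 nM, which is the highest of the two numbers so far; its nearest neighbour is compound 1 `O=C(Nc1ccc(-n2ccc3c(NC(=O)c4ccccc4)ncnc32)cc1)c1ccc(Cl)c(Cl)c1`, which in this assay gives 5000 nM, and the step of a 1.6-fold higher number from compound 1 to compound 2 (0.19 log units; within the scatter) lies within the scatter. Compound 3 `O=C(Nc1ccc(-n2ccc3c(NC(=O)c4ccccc4)ncnc32)cc1)c1cccc(C(F)(F)F)c1` is not yet measured in this assay; it differs from compound 2 by 3-(trifluoromethyl)phenyl in place of (2,3-dichlorophenyl)amino on a carbonyl carbon. For the measured compounds named here, only one measured step bears on this change, and it runs in the other direction over a related but not identical exchange: a 1.6-fold higher number from compound 1 to compound 2 (0.19 log units; within the scatter) turned a carbonyl-linked 3,4-dichlorophenyl into a (2,3-dichlorophenyl)amino without moving the number beyond the scatter. Compound 3 returns to a carbon-linked aryl on that carbonyl, now a 3-(trifluoromethyl)phenyl, so on this evidence the expected step of a 1.4-fold lower number from compound 2 to compound 3 (0.15 log units; within the scatter) is none beyond the scatter, with a slight lean back toward the number of compound 1. The value of compound 3 in this assay is estimated at 5500 nM, within a range of 1800 nM to 17000 nM.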

Compound 3, half-maximal inhibitory concentration: 5900 nM
Beside the measured number, compound 3's estimate is 1.1-fold (0.03 log units) below it; measured number inside the range.
By their numbers in this assay, from the lowest: compounds 1, 3 and 2 (each within the scatter of the next).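

In this assay, placing 3-(trifluoromethyl)phenyl on the carbonyl carbon whose other neighbour is the amide-type nitrogen gives a 1.3-fold lower number from compound 2 to compound 3 (0.12 log units; within the scatter) against (2,3-dichlorophenyl)amino and a 1.2-fold higher number from compound 1 to compound 3 (0.07 log units; within the scatter) against 3,4-dichlorophenyl. This position has now carried three different aryl-bearing groups with every printed step inside the scatter, and the hydrogen-bond donor counted on (2,3-dichlorophenyl)amino is absent from the entering group without the number moving beyond it, so these three compounds show no measurable preference among these groups at this carbonyl carbon. No other data on hand bear on this result.

As far as these compounds go, whether a group of a different kind on this carbonyl carbon, such as a short alkyl chain, a carboxylic acid or an aliphatic amine, would give a step beyond the scatter remains open, since all three groups here carry a six-membered aromatic ring of carbon only. Also open, from the compounds shown here alone, is whether the closeness seen in this assay holds in any other read-out, and whether it persists when the benzoyl amide elsewhere on the shared core is exchanged.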